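Pyridylmethyl and hydroxybenzyl amines on the shared core

A few compounds are considered here, and "the series" means these few. Any claim that something is new, unique, unknown or untested is made for them only; others in the source may bear on it.

Measured in a functional assay on NCI-H460 cells (Homo sapiens) for inhibition, read by CCK-8 assay, with a stated time of 4 days; on this read-out lower numbers stand for stronger inhibition and higher numbers for weaker inhibition:
- compound 1 `COc1cc(C(=O)O)ccc1NC(=O)[C@@H]1N[C@@H](CC(C)(C)C)[C@](CNCc2ccncc2)(c2ccc(Cl)cc2F)[C@H]1c1cccc(Cl)c1F`: 460 nM
- compound 2 `COc1cc(C(=O)O)ccc1NC(=O)[C@@H]1N[C@@H](CC(C)(C)C)[C@](CNCc2ccc(O)cc2)(c2ccc(Cl)cc2F)[C@H]1c1cccc(Cl)c1F`: 670 nM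
- compound 3 `COc1cc(C(=O)O)ccc1NC(=O)[C@@H]1N[C@@H](CC(C)(C)C)[C@](CNCc2ccccn2)(c2ccc(Cl)cc2F)[C@H]1c1cccc(Cl)c1F`: 470 nM

Compound 2 carries the highest of the three numbers shown in this assay, but only by a margin within the scatter: the step of a 1.5-fold higher number from compound 1 to compound 2 (0.16 log units; within the scatter) and the step of a 1.4-fold lower number from compound 2 to compound 3 (0.15 log units; within the scatter) are both too small to read as real differences. The three amine substituents, pyridin-4-yl, 4-hydroxyphenyl and pyridin-2-yl, therefore behave alike on the shared core of compound 1.

Compound 4 `COc1cc(C(=O)O)ccc1NC(=O)[C@@H]1N[C@@H](CC(C)(C)C)[C@](CNCc2cccnc2)(c2ccc(Cl)cc2F)[C@H]1c1cccc(Cl)c1F` is the remaining positional isomer of the pyridyl series. Its difference from compound 2 is pyridin-3-yl in place of 4-hydroxyphenyl on a saturated chain carbon bound to an amine nitrogen. Among the compounds with values here, the steps that bear on it are the two already measured exchanges of the same group: a 1.5-fold higher number from compound 1 to compound 2 (0.16 log units; within the scatter) and a 1.4-fold lower number from compound 2 to compound 3 (0.15 log units; within the scatter), each within the scatter. A pyridin-3-yl ring is expected to sit with the other two pyridyl isomers rather than apart from them, so the number for compound 4 in this assay is expected to be modestly lower than that of compound 2, but not beyond the scatter.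

The expected step of a 1.4-fold lower number from compound 2 to compound 4 (0.14 log units; within the scatter) is small. Compound 4 is estimated at 480 nM, within a range from 250 nM to 950 nM.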

Compound 4, half-maximal inhibitory concentration: 700 nM
Estimate against measurement, compound 4: 1.5-fold (0.16 log units) below, and the stated range covers the measured number.
By their numbers in this assay, from the lowest: compounds 1, 3, 2 and 4 (each within the scatter of the next).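

In this assay the steps of a 1.5-fold higher number from compound 3 to compound 4 (0.17 log units; within the scatter) and a 1.5-fold higher number from compound 1 to compound 4 (0.18 log units; within the scatter) complete the pyridyl set and show that moving the ring nitrogen among pyridin-2-yl, pyridin-3-yl and pyridin-4-yl leaves no readable difference on this saturated chain carbon bound to an amine nitrogen. The step of a 1.0-fold higher number from compound 2 to compound 4 (0.02 log units; within the scatter) adds that 4-hydroxyphenyl, with its hydrogen-bond donor, can give way to pyridin-3-yl, which has none, while the numbers stay within the scatter, so all four aromatic groups on the shared core remain indistinguishable here. Nothing available accounts for this flat response.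

Still open, from the compounds shown here alone, is whether any group at this place can move the number beyond the scatter, since all four compounds carry a single six-membered aromatic ring on a one-carbon link to the amine nitrogen. A carboxylic acid or a dimethylamino group on that ring, a longer chain between the ring and the amine, or a saturated ring such as piperidine would test how far this tolerance extends.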